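The source may report more compounds than this note shows. Statements on the series, on what has been measured and on what is new or still open speak of the compounds shown alone.

Compounds measured in an ADME assay on RAW264.7 cells (Mus musculus) for cytotoxicity, read by MTT assay, with a stated time of 48 h; on this read-out higher numbers stand for weaker inhibition and lower numbers for stronger inhibition:
compound 1 `COc1cc(NC(=O)c2cccc(C(F)(F)F)c2)ccc1NS(=O)(=O)C(F)(F)F` — 75200 nM
compound 2 `CS(=O)(=O)Nc1ccc(NC(=O)c2cccc(C(F)(F)F)c2)cc1Cl` — limit of > 250000 nM
compound 3 `CCS(=O)(=O)Nc1ccc(NC(=O)c2cccc(C(F)(F)F)c2)cc1Cl` — 62400 nM

Compound 2 gives only a limit in this assay, as stated at the limit of > 250000 nM in this assay, at which 1 of the 3 values shown sits. Among the two numbers, compound 3 has the lowest, and compound 1 lies within the scatter of it. For the measured compounds named here, the one measured step on the sulfonyl chain, an at least 4.0-fold lower number from compound 2 to compound 3 (0.60 log units; beyond the scatter), went from a limit to a number. Compound 4 `O=C(Nc1ccc(NS(=O)(=O)C(F)(F)F)c(Cl)c1)c1cccc(C(F)(F)F)c1` differs from compound 3 by trifluoromethyl in place of ethyl on a sulfonyl sulfur. Compound 1 also carries a (trifluoromethyl)sulfonyl group, and its number sits close to that of compound 3, so in this assay the step from compound 3 to compound 4 is expected to be a 1.0-fold higher number from compound 3 to compound 4 (0.02 log units; within the scatter), not beyond the scatter. Compound 4 is therefore estimated at 65000 nM, in the range 25000 nM to 170000 nM.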

Compound 4, half-maximal inhibitory concentration: 55800 nM
Beside the measured number, compound 4's estimate is 1.2-fold (0.07 log units) above it; the measured number falls inside the stated range.
By their numbers in this assay, from the lowest: compounds 4, 3 and 1 (each within the scatter of the next). At a limit, above all of these: compound 2.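

In this assay, trifluoromethyl and ethyl on the sulfonyl sulfur give numbers within the scatter of each other (a 1.1-fold lower number from compound 3 to compound 4 (0.05 log units; within the scatter)). With the (trifluoromethyl)sulfonyl group held, chloro in place of methoxy on an aromatic carbon also stays within the scatter (a 1.3-fold lower number from compound 1 to compound 4 (0.13 log units; within the scatter)). For the compounds shown here, compound 2 gives only a limit, so the one new step beyond the scatter (an at least 4.4-fold lower number from compound 2 to compound 4 (0.65 log units; beyond the scatter)) is a bound, not a size: the limit of > 250000 nM in this assay, at which 1 of the 4 values shown sits.

From the compounds shown here alone, whether a longer chain or an amine on the sulfonyl sulfur would stay within this scatter remains open. So does the effect of a carboxylic acid in place of chloro.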